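The compounds below may be only part of what the source reports. "The series", "measured", "known", "first", "only" and "open" are said of these compounds alone.

Working notes on the series.

Three compounds have numbers in a functional assay on the whole organism with Rattus norvegicus as the target, at a dose of 100 mg/kg; on this read-out lower numbers stand for less inhibition and higher numbers for more inhibition at the one dose given (going by the name of the read-out). Compound 1 `C/N=C(\S)NCCCCCn1nc(-c2ccccc2)ccc1=O` gives 68.9%. Within the data shown here, compound 3 `CCC/N=C(/NC#N)NCCCCCn1nc(-c2ccccc2)ccc1=O` gives 27.5%; the only one-place step measured so far is a number 41.4 percentage points lower from compound 1 to compound 3 (beyond the scatter), a change of a group on an amine nitrogen. Compound 2 `O=c1ccc(-c2ccccc2)nn1CCCCNC(=S)NC1CCCCC1` gives 18.1%. Compound 2 stands at the low end of the three: compound 1 lies beyond the scatter above it, while compound 3 sits within the scatter of it, so no order between compound 2 and compound 3 can be read.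

Compound 4 `O=c1ccc(-c2ccccc2)nn1CCCCNC(=S)Nc1ccccc1` is not yet measured. The change from compound 2 to compound 4 is phenyl in place of cyclohexyl on an amide-type nitrogen, with the thiocarbonyl carbon and the rest of the chain and core kept. Among the measured compounds shown here, no measured step touches this place or this kind of exchange; the step from compound 1 to compound 3 concerns a different nitrogen and a different pair of groups, so it does not bear on it. With nothing to indicate a direction, the expected step of a number 3.9 percentage points higher from compound 2 to compound 4 (within the scatter) is none beyond the scatter, and compound 4 is estimated at 22%, with a range from 5% to 45% to cover the uncertainty of an untested exchange.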

Compound 4, a percentage reported as inhibition, in the whole organism at one dose (the size of the read-out at that dose, not a potency): 38.4%
Compound 4: middle estimate off by 16.4 percentage points, on the low side; the measured number falls inside the stated range.
By their numbers in this assay, from the lowest: compounds 2 and 3 (each within the scatter of the next); then compound 4; then compound 1.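

In this assay, phenyl in place of cyclohexyl on an amide-type nitrogen gives a number 20.3 percentage points higher from compound 2 to compound 4 (beyond the scatter), the first measured sign that the group at this place affects the read-out while the thiocarbonyl carbon, chain and core stay the same. The two groups have the same count of heavy atoms and neither carries a hydrogen-bond donor or acceptor, so the difference counted between them is an aromatic ring in place of a non-aromatic ring of carbon only. No measurement available here accounts for the step, and this single pair sets no trend for the position.

Among these compounds, compound 1 and compound 3 differ from compound 4 in more than one place, so no steps to them can be read, and it remains open whether the same exchange would give a step of similar direction and size with a longer chain. Also open, as far as these compounds go, is where a benzyl group, a pyridyl ring or a chlorophenyl group on this nitrogen would fall relative to phenyl and cyclohexyl, which would show whether the step extends beyond this one pair.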